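The source may report more compounds than this note shows. Statements on the series, on what has been measured and on what is new or still open speak of the compounds shown alone.

Of the compounds shown here, three from one series have been tested so far, all carrying the same sulfonamide-linked core and differing in where a chlorine sits on a benzoyl group and in how the pieces of the molecule are joined. Compound 1 `O=C(NNC(=O)c1ccccc1Cl)c1cccc(NS(=O)(=O)c2cnc(O)nc2O)c1` gives 7300 nM in a functional assay on OVCAR-3 cells (Homo sapiens) for antiproliferative activity, read by MTT assay, with a stated time of 24 h; a higher number here means a weaker inhibitor, a lower number a stronger inhibitor. Compound 2 `O=C(NNC(=O)c1cccc(NS(=O)(=O)c2cnc(O)nc2O)c1)c1cccc(Cl)c1` gives 13500 nM in this assay. The change from compound 1 to compound 2 is 3-chlorophenyl in place of 2-chlorophenyl on a carbonyl carbon, and it produced a 1.8-fold higher number from compound 1 to compound 2 (0.27 log units; within the scatter). Compound 3 `O=C(NNC(=O)c1ccccc1NS(=O)(=O)c1cnc(O)nc1O)c1ccccc1Cl` gives 18200 nM in this assay; its value stands closest to that of compound 2 and furthest from that of compound 1. The difference between the core of compound 1 and the core of compound 3 is not broken down here.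

Compound 4 `O=C(NNC(=O)c1ccccc1NS(=O)(=O)c1cnc(O)nc1O)c1cccc(Cl)c1` has not yet been measured. It relates to compound 3 exactly as compound 2 relates to compound 1: the change is 3-chlorophenyl in place of 2-chlorophenyl on a carbonyl carbon, made at the same kind of position, so it is the same change seen a second time. Among the measured compounds shown here, since the only earlier instance of this change gave a 1.8-fold higher number from compound 1 to compound 2 (0.27 log units; within the scatter), a step of similar size is expected here, namely a 1.6-fold higher number from compound 3 to compound 4 (0.22 log units; within the scatter). On that basis compound 4 is expected to give about 30000 nM in this assay, most likely between 15000 nM and 60000 nM, with the caution that one prior example of a change lying within the scatter is a thin foundation for any prediction.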

Compound 4, half-maximal inhibitory concentration: 2080 nM
The estimate for compound 4 lay 14-fold (1.16 log units) above the measured number; the measured number lies below the stated range.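

In this assay, replacing 2-chlorophenyl with 3-chlorophenyl on the carbonyl carbon gave an 8.8-fold lower number from compound 3 to compound 4 (0.94 log units; beyond the scatter), a clear change on this core. Set beside its only earlier instance, the same replacement did not carry over from one core to the other with a similar effect: the same change on two cores in this assay, a 1.8-fold higher number (0.27 log units; within the scatter) from compound 1 to compound 2 and an 8.8-fold lower number (0.94 log units; beyond the scatter) from compound 3 to compound 4, 16-fold (1.21 log units) apart, beyond the scatter of two such steps. This shows that, in these four compounds, the step measured on one core was a poor guide to the step on the other, but it does not show which structural difference between the cores is responsible, and two pairs are too few to give a rule for any further core.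

Still open, from the compounds shown here alone, is how a phenyl ring carrying an amine or a carboxylic acid in place of the chlorine would behave on each of the two cores, which would help show whether this gap between the cores is specific to the chlorophenyl pair. Also open, going by these compounds, is whether the same gap would appear in other cell lines or with a different exposure time.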